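A few compounds are considered here, and "the series" means these few. Any claim that something is new, unique, unknown or untested is made for them only; others in the source may bear on it.

Compound 1 `CN(CCC#N)C[C@H]1CN(c2ccc(-n3cc(-c4ccccn4)cn3)c(F)c2)C(=O)O1` gives > 400 ug/mL in an ADME assay on L02 cells (Homo sapiens) for cytotoxicity, read by MTT assay, with a stated time of 48 h; a lower number here means a stronger inhibitor, a higher number a weaker inhibitor; this is a limit of the assay, not a number.
Compound 2 `COC[C@H]1CN(c2ccc(-n3cc(-c4ccccn4)cn3)c(F)c2)C(=O)O1` gives > 400 ug/mL in this assay; this too is a limit.

Compound 2 therefore stands at the top of what this assay can report: no measured number, only a limit, the same as for compound 1. For the measured compounds named here, the one step between measured compounds, a step that the two limits leave unreadable from compound 1 to compound 2, cannot be read in size or direction because of the limit of > 400 ug/mL in this assay, at which 2 of the 2 values shown sit.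

Compound 3 `O=C1O[C@@H](Cn2ccnc2)CN1c1ccc(-n2cc(-c3ccccn3)cn2)c(F)c1` differs from compound 2 in a single place: 1H-imidazol-1-yl in place of methoxy on a saturated chain carbon bound to a saturated ring carbon. Going by the values given here, no measured step gives a readable size for any change at this position, so there is nothing beyond the fact that both measured compounds sit at the limit to build on. On that basis the expectation for compound 3 in this assay is no step beyond the usual scatter, expressed as a number no higher from compound 2 to compound 3 (the limit leaves the size open), with the most likely outcome being a limit again. The estimate for compound 3 is 400 ug/mL, expected to fall between 200 ug/mL and 800 ug/mL.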

Compound 3, half-maximal inhibitory concentration: 350 ug/mL
The estimate for compound 3 lay 1.1-fold (0.06 log units) above the measured number; low and high end bracket the measured number.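

Compound 3 gives 350 ug/mL in this assay, which makes it the only compound shown with a real reading at this place, on a saturated chain carbon bound to a saturated ring carbon. Putting 1H-imidazol-1-yl in place of methoxy gives an at least 1.1-fold lower number from compound 2 to compound 3 (0.05 log units; that floor lies within the scatter), and putting it in place of (2-cyanoethyl)(methyl)amino gives an at least 1.1-fold lower number from compound 1 to compound 3 (0.05 log units; that floor lies within the scatter). With this five-membered aromatic ring in place the result falls within what the assay can report, but neither step can be called a real change, and each has only a floor and no full size, because the other two results are limits: the limit of > 400 ug/mL in this assay, at which 2 of the 3 values shown sit.

Going by these compounds, the step from compound 1 to compound 2 still cannot be read, and with a single imidazole example it remains open whether the aromatic ring matters, or simply the larger group, or neither. A plain primary amine, a carboxylic acid or a longer chain at the same carbon would show whether any group here can give a reading clearly beyond the scatter of the assay.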